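A Chloro Swap Where Every Number Is a Limit

The source may hold more compounds than are shown below. What is called first, only, known or untested is meant among the compounds shown, and "the series" means these compounds.

Compound 2 `Cc1nc(Nc2ccccc2)sc1C(=O)/C=C/c1ccccc1` is the unsubstituted parent of this small set. In a functional assay on PC-3 cells (Homo sapiens) for cytotoxicity, read by MTT assay (on this read-out lower numbers stand for stronger inhibition and higher numbers for weaker inhibition), compound 2 gives > 25000 nM, which is a limit of the assay rather than a number. Compound 1 `Cc1nc(Nc2cccc(Cl)c2)sc1C(=O)/C=C/c1ccc(Cl)cc1` carries two chloro groups; in this assay compound 1 gives > 25000 nM, again only a limit. Compound 3 `Cc1nc(Nc2ccccc2)sc1C(=O)/C=C/c1ccccc1Cl` is reached from compound 2 by chloro in place of hydrogen on an aromatic carbon; in this assay compound 3 gives > 25000 nM, also a limit. Within the data shown here, the one measured step, a step that the two limits leave unreadable from compound 2 to compound 3, therefore cannot be sized. Compound 4 `Cc1nc(Nc2cccc(Cl)c2)sc1C(=O)/C=C/c1ccccc1` differs from compound 2 by chloro in place of hydrogen on an aromatic carbon. Among the measured compounds shown here, no measured step covers this exact change, and the only bearing comes from the limit of > 25000 nM in this assay, at which 3 of the 3 values shown sit; compounds 1 and 4 differ by a single chloro group, and the value of compound 1 is itself a limit. Compound 4 is accordingly expected to sit at the limit as well, with an estimated value of 40000 nM (range 25000 nM to 100000 nM). The step that the limit leaves unreadable from compound 2 to compound 4 is thus expected to be one that the limit leaves unreadable.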

Compound 4, half-maximal inhibitory concentration: > 25000 nM
Compound 4: only a limit was reported; the forecaster's own chance of this, stated with the estimate: 85%; the middle value does not contradict the limit.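

Neither the step from compound 2 to compound 4 nor the step from compound 1 to compound 4 can be read, because each value is only a limit: the limit of > 25000 nM in this assay, at which 4 of the 4 values shown sit.

The compounds shown leave open how far past this limit each one lies, and so whether a chloro group changes the read-out at all.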